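Clearance notes on the nitro-trifluoromethyl thiazole series

The source may report more compounds than this note shows. Statements on the series, on what has been measured and on what is new or still open speak of the compounds shown alone.

Measured compounds:
- compound 1, `O=C(c1sc2c([N+](=O)[O-])cc(C(F)(F)F)cc2[n+]1[O-])N1CCCCC1`: in an ADME assay on liver (Mus musculus) for metabolic stability, using microsomes (a higher number here means faster removal of the compound, a lower number slower removal), compound 1 gives 102 mL.min-1.g-1
- compound 2, `Cc1c(C(F)(F)F)cc2nc(C3=N[C@H](C(=O)N4CCCC4)CO3)sc2c1[N+](=O)[O-]`: in this assay compound 2 gives 37.9 mL.min-1.g-1

Going by the values given here, of the two numbers so far, compound 2 stands lowest; the only other value, that of compound 1, is higher by a margin beyond the usual scatter of this assay. Among the compounds with values here, compound 1 and compound 2 differ in several places at once, so no single step between them is isolated, and their two values show only that the shared core tolerates a wide span of clearance.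

The next compound, compound 3, `O=C([C@@H]1COC(c2nc3cc(C(F)(F)F)cc([N+](=O)[O-])c3s2)=N1)N1CCCC1`, differs from compound 2 in one place only: hydrogen in place of methyl on an aromatic carbon. Within the data shown here, no pair of measured compounds shows what this change does in this assay. With nothing to anchor the step, the expectation is that the step from compound 2 to compound 3, estimated as a 1.2-fold lower number from compound 2 to compound 3 (0.07 log units; within the scatter), stays within the scatter, in no firm direction. On that basis compound 3 is estimated at 32 mL.min-1.g-1 in this assay, with a range from 12 mL.min-1.g-1 to 85 mL.min-1.g-1.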

Compound 3, intrinsic clearance in microsomes in the Mus musculus assay: 76.6 mL.min-1.g-1
Beside the measured number, compound 3's estimate is 2.4-fold (0.38 log units) below it; the measured number falls inside the stated range.
By their numbers in the Mus musculus assay, from the lowest: compound 2; then compounds 3 and 1 (each within the scatter of the next).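

At this aromatic carbon, ortho to a nitro group and ortho to a trifluoromethyl group, the choice of substituent registers in clearance: in the Mus musculus assay, hydrogen in place of methyl gives a 2.0-fold higher number from compound 2 to compound 3 (0.31 log units; beyond the scatter), a modest step that nonetheless lies beyond the scatter. In a physicochemical assay for solubility (a higher number here means a more soluble compound, a lower number a less soluble compound), compound 2 gives 12000 nM and compound 3 gives 64600 nM, so this position also bears on a second read-out. The single change therefore goes with faster removal and with higher solubility together, leaving compound 2 with the slower removal and compound 3 with the higher solubility: the measured solubility of compound 2, 12000 nM, and of compound 3, 64600 nM, a 5.4-fold higher number (0.73 log units; beyond the scatter)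

As far as these compounds go, this trade-off rests on one pair with the same pyrrolidine amide, so it remains open whether it would hold with the other end of the molecule changed or is particular to this pair. From the compounds shown here alone, it also remains open whether a chlorine atom, a methoxy group or an ethyl chain on this aromatic carbon would follow methyl, follow hydrogen, or separate the two read-outs.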